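Notes on compound 3 as a variant of compound 2

The source may report more compounds than this note shows. Statements on the series, on what has been measured and on what is new or still open speak of the compounds shown alone.

Measured so far:
compound 1 `COCCNC(=O)c1cc2cccc(OC)c2oc1=O` — 18%
compound 2 `COc1cccc2cc(C(=O)NCC(O)CO)c(=O)oc12` — 25%

Compound 2 gives the higher of the two numbers in an assay on HEK293 cells for displacement of a labelled ligand from adenosine receptor A2b (Homo sapiens), read by scintillation counting, with a stated time of 30 min, tested at 10 uM (on this read-out lower numbers stand for less inhibition and higher numbers for more inhibition at the one concentration tested (going by the name of the read-out)), with compound 1 nearest; the step of a number 7 percentage points higher from compound 1 to compound 2 (within the scatter) lies within the scatter. Compound 3 `O=C(NCC(O)CO)c1cc2cccc(O)c2oc1=O` differs from compound 2 by hydrogen in place of methyl on an oxygen on an aromatic ring. Among the compounds with values here, no measured step bears on this change: the only measured step concerns the chain on the amide nitrogen, not the oxygen on the aromatic ring. With nothing to carry across, the expected step is a number 3 percentage points lower from compound 2 to compound 3 (within the scatter), not beyond the scatter. Compound 3 is therefore estimated at 22%, within 5% to 45%.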

Compound 3, a percentage reported as inhibition, at one concentration (the size of the read-out at that concentration, not a potency): 29%
For compound 3 the middle estimate is 7 percentage points below the measured one; low and high end bracket the measured number.
By their numbers in this assay, from the lowest: compounds 1, 2 and 3 (each within the scatter of the next, the first and the last beyond it).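

Methoxy to hydroxy on the aromatic ring gives a number 4 percentage points higher from compound 2 to compound 3 (within the scatter) in this assay and is the first reading at this oxygen, as the earlier step concerned only the chain on the amide nitrogen. At this position, then, hydrogen in place of methyl leaves the number within the scatter on the diol chain of compound 2. No supporting data bear on this result. As far as these compounds go, whether an amine or a longer alkoxy chain here would move the number beyond the scatter stays open, as does whether the same change reads alike with the chain of compound 1.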